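Working notes on one measured series and one expected compound

The compounds below may be only part of what the source reports. "The series", "measured", "known", "first", "only" and "open" are said of these compounds alone.

Measured in an ADME assay on Vero cells (Chlorocebus sabaeus) for cytotoxicity, read by MTT assay, with a stated time of 72 h; a lower number here means a stronger inhibitor, a higher number a weaker inhibitor:
compound 1 `O=C(NNC(=S)NCc1ccccc1)c1cc([N+](=O)[O-])c[nH]1` gives 397000 nM
compound 2 `O=C(NCc1ccco1)NNC(=O)c1cc([N+](=O)[O-])c[nH]1` gives 443000 nM
compound 3 `Cn1cc([N+](=O)[O-])cc1C(=O)NNC(=S)Nc1ccc([N+](=O)[O-])cc1` gives 395000 nM

Compound 1 holds the second highest of the three numbers in this assay; compound 3 is nearest and compound 2 furthest, and both lie within the scatter of compound 1, so the three cannot be ordered. Compound 4 `O=C(NNC(=S)Nc1ccc(F)cc1)c1cc([N+](=O)[O-])c[nH]1` differs from compound 1 by 4-fluorophenyl in place of benzyl on an amide-type nitrogen. Going by the values given here, no step between two measured compounds that differ in one place exists here; the three measured compounds vary in several places at once and still stay together within the scatter. The step of a 1.0-fold higher number from compound 1 to compound 4 (0.00 log units; within the scatter) is therefore expected to be none beyond the scatter. Compound 4 is estimated at 400000 nM, with a range from 200000 nM to 800000 nM.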

Compound 4, half-maximal inhibitory concentration: 331000 nM
Compound 4: middle estimate off by 1.2-fold (0.08 log units), on the high side; the measured number falls inside the stated range.
By their numbers in this assay, from the lowest: compounds 4, 3, 1 and 2 (each within the scatter of the next).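

On the amide-type nitrogen whose other neighbour is the thiocarbonyl carbon, the series now has its first comparison in one place in this assay: 4-fluorophenyl in place of benzyl gives a 1.2-fold lower number from compound 1 to compound 4 (0.08 log units; within the scatter). The two groups have the same heavy-atom count and one aromatic ring each, and this exchange gives no readable difference in this assay. Nothing available bears on a reason for this result. Still open, going by these compounds, is whether a phenethyl chain or a phenyl ring carrying a carboxylic acid on this nitrogen would also stay within the scatter of compound 1.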